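A few compounds are considered here, and "the series" means these few. Any claim that something is new, unique, unknown or untested is made for them only; others in the source may bear on it.

Four compounds share one core and differ only in a single group. Compound 1 `CS/C(=C/C(=O)c1ccc(C)cc1)Nc1nc2ccccc2s1` carries methyl there; in an assay on isolated protein for inhibition of lysosomal alpha-glucosidase (Homo sapiens) (a higher number here means a weaker inhibitor, a lower number a stronger inhibitor), compound 1 gives 21100 nM. Compound 2 `CS/C(=C/C(=O)c1ccc(Br)cc1)Nc1nc2ccccc2s1` carries bromo, and in this assay compound 2 gives "not active" (no number reported), a result reported without a number. Compound 3 `CS/C(=C/C(=O)c1ccc(Cl)cc1)Nc1nc2ccccc2s1` carries chloro; in this assay compound 3 gives "not active" (no number reported), again without a number. No single value therefore fixes where compound 3 stands, and compound 2 is the one further entry in the same state, so compound 1 alone supplies a figure against which the rest can be set.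

Compound 4 `CS/C(=C/C(=O)c1ccc(F)cc1)Nc1nc2ccccc2s1` is the next member of the set: fluoro in place of chloro on an aromatic carbon. Within the data shown here, no measured pair shows what a step of this kind does here. With chloro and bromo both leaving no number, and with the methyl of compound 1 giving only a weak value of 21100 nM, there is no ground for expecting compound 4 to move far in either direction; any change is expected to stay within the scatter or to end again without a number. Compound 4 is accordingly estimated to give about 40000 nM, with a range from 15000 nM to 150000 nM, and with a real chance that only a limit is reported.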

Compound 4, half-maximal inhibitory concentration: "not active" (no number reported)
Nothing numeric was reported for compound 4; the estimate stays without a comparison.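

Among these compounds, compound 4, like compound 3, gives no number in this assay, so no step from chloro to fluoro can be read between them. The compounds shown leave open how far compound 2, compound 3 and compound 4 lie from compound 1 at 21100 nM in this measurement. Nothing available bears on this result.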